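Methoxy on the phenyl ring of a triazole sulfone

A few compounds are considered here, and "the series" means these few. Any claim that something is new, unique, unknown or untested is made for them only; others in the source may bear on it.

The measured compounds:
compound 1, `Cn1c(-c2cccc(F)c2)nnc1S(C)(=O)=O`, 12.1 mg/kg
compound 2, `Cn1c(-c2ccccc2)nnc1S(C)(=O)=O`, 12.8 mg/kg
compound 3, `CC[S+]([O-])c1nnc(-c2ccccc2)n1C`, 14.4 mg/kg

Of the compounds shown here, three share a core and have been measured in a functional assay on the whole organism for antagonist activity, with Mus musculus as the target; on this read-out higher numbers stand for an effect only at larger amounts of compound and lower numbers for an effect already at smaller amounts. Compound 1 carries a fluoro on its phenyl ring; in this assay compound 1 gives 12.1 mg/kg. Compound 2 has hydrogen there and gives 12.8 mg/kg. Compound 3 has a different sulfur group and gives 14.4 mg/kg. Compound 2 stands with its number inside the scatter of both neighbours: a 1.1-fold higher number from compound 1 to compound 2 (0.02 log units; within the scatter) and a 1.1-fold higher number from compound 2 to compound 3 (0.05 log units; within the scatter).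

Compound 4, `COc1ccc(-c2nnc(S(C)(=O)=O)n2C)cc1`, is not yet measured. It differs from compound 2 in one place: methoxy in place of hydrogen on an aromatic carbon, on an aromatic carbon of a six-membered aromatic ring of carbon only, para to a large group. Among the compounds with values here, no measured step brings a methoxy in. The nearest comparison is the change on the same ring from compound 1 to compound 2, which stayed within the scatter, as did the step from compound 2 to compound 3. For compound 4 no step beyond the scatter in this assay is therefore expected, a 1.0-fold higher number from compound 2 to compound 4 (0.01 log units; within the scatter). Compound 4 is estimated at 13 mg/kg, between 7 mg/kg and 26 mg/kg.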

Compound 4, dose for half-maximal effect: > 200 mg/kg
Compound 4: no number, only a limit; the forecaster's own chance of this, stated with the estimate: 5%; middle value at least 15-fold (1.18 log units) from the limit.
By their numbers in this assay, from the lowest: compounds 1, 2 and 3 (each within the scatter of the next). At a limit, above all of these: compound 4.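

Methoxy in place of hydrogen, on an aromatic carbon para to a large group, gives an at least 15-fold higher number from compound 2 to compound 4 (1.19 log units; beyond the scatter) in this assay, the only step among these compounds that lies beyond the scatter. Within the data shown here, the phenyl ring is therefore not as tolerant of change as the earlier compounds suggested, since the exchange of fluoro for hydrogen on that ring, a 1.1-fold higher number from compound 1 to compound 2 (0.02 log units; within the scatter), and the change in the sulfur group, a 1.1-fold higher number from compound 2 to compound 3 (0.05 log units; within the scatter), had both stayed within the scatter. The result for compound 4 is a limit and not a number: the limit of > 200 mg/kg in this assay, at which 1 of the 4 values shown sits.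

What the compounds shown cannot tell is why methoxy has this effect, or whether it is specific to methoxy. From the compounds shown here alone, whether methyl, chloro, hydroxyl or an amine on the same carbon would behave like hydrogen or like methoxy stays open, as does the effect of methoxy on any other carbon of the ring.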